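This account rests on a few compounds, and the source may have more. Where it says the series, first, only, none or still open, it means among the compounds named here.

In an ADME assay on BaF3 cells (Mus musculus) for antiproliferative activity (on this read-out lower numbers stand for stronger inhibition of growth and higher numbers for weaker inhibition of growth), three compounds have been measured so far, and none of them gives a number. Compound 1 `Cc1ccc(NC(=O)c2cccc(C(F)(F)F)c2)cc1OCCNC(=O)c1ccno1` reaches only a limit, > 10000 nM. Compound 2 `Cc1ccc(NC(=O)c2cccc(C(F)(F)F)c2)cc1OC1CCN(C(=O)c2cccnc2)CC1` also reaches only a limit, > 10000 nM. Compound 3 `O=C(Nc1cccc(OC2CCN(C(=O)c3cccnc3)CC2)c1)c1cccc(C(F)(F)F)c1` likewise stops at a limit, > 10000 nM. Compound 3 therefore stands with the others at the limit of > 10000 nM in this assay, at which 3 of the 3 values shown sit. Compound 4 `O=C(Nc1ccc(Cl)c(OC2CCN(C(=O)c3cccnc3)CC2)c1)c1cccc(C(F)(F)F)c1` differs from compound 3 by one change: chloro in place of hydrogen on an aromatic carbon. Going by the values given here, the one measured step that bears on this is a step that the two limits leave unreadable from compound 2 to compound 3, which offers no size to carry over. No shift beyond the scatter is therefore expected, and the estimated step is a number no higher from compound 3 to compound 4 (the limit leaves the size open). The expected value for compound 4 is 10000 nM, with an estimated range from 3000 nM to 20000 nM.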

Compound 4, concentration for 50% growth inhibition: > 10000 nM
Compound 4 ended at the assay's limit; the forecaster's own chance of this, stated with the estimate: 70%; the middle value lies on the limit itself.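

Going by these compounds alone, compound 2, compound 3 and compound 4 all stop at a limit, so no step among them can be read: the limit of > 10000 nM in this assay, at which 4 of the 4 values shown sit. The compounds shown leave open which change to the shared core, if any, would give a number rather than a limit in this assay.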